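From but-3-en-1-yl to 4-chlorobenzyl on the shared core

The source may hold more compounds than are shown below. What is called first, only, known or untested is meant among the compounds shown, and "the series" means these compounds.

Compound 1 (`CCCCOc1ccc(C(O)C2OC(=O)c3c(OC)cc(OC)cc32)cc1`): > 40000 nM as a limit
Compound 2 (`C=CCCOc1ccc(C(O)C2OC(=O)c3c(OC)cc(OC)cc32)cc1`): > 40000 nM as a limit

Both entries come from an ADME assay on RAW264.7 cells (Mus musculus) for cytotoxicity, read by MTT assay, with a stated time of 24 h, in the absence of a further agent (a lower number here means a stronger inhibitor, a higher number a weaker inhibitor), and neither is a number. Compound 2 stands on the numbers only as > 40000 nM and this is a limit. Compound 1 offers the one other entry, which is also a limit.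

Compound 3 (`COc1cc(OC)c2c(c1)C(C(O)c1ccc(OCc3ccc(Cl)cc3)cc1)OC2=O`) differs from compound 2 in a single place: 4-chlorophenyl in place of allyl on a saturated chain carbon bound to an oxygen on an aromatic ring with 4-chlorophenyl in place of allyl on a saturated chain carbon bound to an oxygen on an aromatic ring. Cut one bond further out, the change reads but-3-en-1-yl to 4-chlorobenzyl.

Among the compounds with values here, the only measured step that bears on it is a step that the two limits leave unreadable from compound 1 to compound 2 and it has no readable size. The two compounds share the limit of > 40000 nM in this assay, at which 2 of the 2 values shown sit, and so give no size or direction to carry over. Compound 3 is therefore expected most probably to remain a limit in this assay as well, although a readable value cannot be ruled out. The estimate means a number no higher from compound 2 to compound 3 (the limit leaves the size open) as the expected step. For compound 3 the estimate is 40000 nM with an expected range from 15000 nM to 80000 nM in this assay.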

Compound 3, half-maximal inhibitory concentration: > 40000 nM
Compound 3 gave a limit, no number (the forecaster's own chance of this, stated with the estimate: 65%); the middle value lies on the limit itself.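

No step among compound 1, compound 2 and compound 3 can be read in this assay, since each entry is a limit and not a number: the limit of > 40000 nM in this assay, at which 3 of the 3 values shown sit.

The compounds shown leave open how far apart these three lie in this assay, and whether any other group in this place on the shared core would give a readable value.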